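The compounds below may be only part of what the source reports. "The series", "measured", "known", "first", "only" and "open" are said of these compounds alone.

Working notes on the anilino series in a functional assay on ECa-109 cells for inhibition, with ECa-109 cell line (Homo sapiens) as the target, read by sulforhodamine B assay; on this read-out higher numbers stand for weaker inhibition and lower numbers for stronger inhibition.

Three compounds are measured. Compound 1 `Cc1ccc(NC2=CC(=O)c3nc4n(c3C2=O)[C@H]2OC[C@@H](O)[C@H]2OC4)cc1` gives 3480 nM. Compound 2 `CCc1ccc(NC2=CC(=O)c3nc4n(c3C2=O)[C@H]2OC[C@@H](O)[C@H]2OC4)cc1` gives 3080 nM. Compound 3 `O=C1C=C(Nc2ccccc2)C(=O)c2c1nc1n2[C@H]2OC[C@@H](O)[C@H]2OC1` gives 4970 nM. The steps of a 1.1-fold lower number from compound 1 to compound 2 (0.05 log units; within the scatter), a 1.4-fold higher number from compound 1 to compound 3 (0.15 log units; within the scatter) and a 1.6-fold higher number from compound 2 to compound 3 (0.21 log units; within the scatter) all fall within the scatter, so the three numbers are not separable and compound 3 sits together with the other two.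

Compound 4 `O=C1C=C(Nc2cccc(Cl)c2)C(=O)c2c1nc1n2[C@H]2OC[C@@H](O)[C@H]2OC1` is not yet measured. It differs from compound 3 by chloro in place of hydrogen on an aromatic carbon, that is phenyl to 3-chlorophenyl, the chloro sitting meta to a large group on the six-membered aromatic ring of carbon only.

Going by the values given here, only the steps of a 1.4-fold higher number from compound 1 to compound 3 (0.15 log units; within the scatter) and a 1.6-fold higher number from compound 2 to compound 3 (0.21 log units; within the scatter) bear on a change at this ring, and both were within the scatter; no measured step puts a chloro on the ring at all, and none changes the ring meta to the large group. The expected step of a 1.1-fold lower number from compound 3 to compound 4 (0.04 log units; within the scatter) is therefore none beyond the scatter, with the range kept wide. For compound 4 the estimate is 4500 nM, between 1800 nM and 11000 nM.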

Compound 4, half-maximal inhibitory concentration: 4690 nM
Compound 4: middle estimate off by 1.0-fold (0.02 log units), on the low side; the range from low to high includes it.
By their numbers in this assay, from the lowest: compounds 2, 1, 4 and 3 (each within the scatter of the next).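

In this assay, going by these compounds alone, the chloro is the first halogen on this ring, and a 1.1-fold lower number from compound 3 to compound 4 (0.03 log units; within the scatter) puts chloro in place of hydrogen, on an aromatic carbon meta to a large group, with no change that can be separated from the scatter. The 3-chlorophenyl also stays within the scatter of both alkyl-bearing rings, with a 1.3-fold higher number from compound 1 to compound 4 (0.13 log units; within the scatter) and a 1.5-fold higher number from compound 2 to compound 4 (0.18 log units; within the scatter), so the four compounds remain one unseparated group and the ring has not yet shown a substituent that moves the read-out. No measurement at hand offers an explanation for these numbers.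

Still open, as far as these compounds go, is whether any change on this ring can move the number beyond the scatter. An amine or a carboxylic acid in place of the chloro, or a chain longer than ethyl, would bear on that question.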